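The compounds below may be only part of what the source reports. "The series", "measured", "known", "first", "only" and "open" are said of these compounds alone.

Compound 2 `CCCn1c(=O)c2nc(-c3cnccn3)[nH]c2n(CCC)c1=O` gives 600 nM in an assay on membranes from brain for antagonist activity at adenosine receptor A1 (Rattus norvegicus) (on this read-out higher numbers stand for weaker inhibition and lower numbers for stronger inhibition), which places it within the scatter of compound 1 `CCCn1c(=O)c2nc(C3CCNCC3)[nH]c2n(CCC)c1=O`, which gives 620 nM in this assay. Within the data shown here, the only measured step, a 1.0-fold lower number from compound 1 to compound 2 (0.01 log units; within the scatter), lies within the scatter. Compound 3 `CCCn1c(=O)c2nc(CC3CCCCC3)[nH]c2n(CCC)c1=O` differs from compound 2 in one place: cyclohexylmethyl in place of pyrazin-2-yl on an aromatic carbon. Among the measured compounds shown here, no measured step covers such an exchange, so the expected size of the step is uncertain. Compound 3 is estimated at 150 nM, with a range from 20 nM to 1000 nM, which would mean an expected step of a 4.0-fold lower number from compound 2 to compound 3 (0.60 log units; beyond the scatter).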

Compound 3, antagonist equilibrium constant: 39 nM
Compound 3: middle estimate off by 3.8-fold (0.59 log units), on the high side; the measured number falls inside the stated range.
By their numbers in this assay, from the lowest: compound 3; then compounds 2 and 1 (each within the scatter of the next).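

The two earlier groups, piperidin-4-yl and pyrazin-2-yl, gave values within the scatter of each other, so this aromatic carbon could have seemed indifferent to what it carries. Cyclohexylmethyl brings a 15-fold lower number from compound 2 to compound 3 (1.19 log units; beyond the scatter) and a 16-fold lower number from compound 1 to compound 3 (1.20 log units; beyond the scatter) in this assay and so shows that the group here can matter a great deal. No measurement at hand explains this gain.

From the compounds shown here alone, what a directly attached cyclohexyl, a phenyl or a longer chain ending in cyclohexyl would give here remains open. So does whether the ring or its methylene link counts more.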